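From 3-hydroxyphenyl to 4-hydroxyphenyl on a trifluoromethoxyphenyl analogue

The source may report more compounds than this note shows. Statements on the series, on what has been measured and on what is new or still open speak of the compounds shown alone.

Compound 1 `Oc1ccc(-c2cc(-c3cccc(F)c3)cc(-c3ccccc3O)n2)cc1`: > 50000 nM in a functional assay on HCT-15 cells (Homo sapiens) for inhibition (a higher number here means a weaker inhibitor, a lower number a stronger inhibitor), a limit of the assay rather than a number.
Compound 2 `Oc1cccc(-c2cc(-c3cccc(OC(F)(F)F)c3)cc(-c3ccccc3O)n2)c1`: 2740 nM in this assay.

Within the data shown here, compound 2 gives the only numerical value here. The remaining result is a limit (the limit of > 50000 nM in this assay, at which 1 of the 2 values shown sits). Compound 3 `Oc1ccc(-c2cc(-c3cccc(OC(F)(F)F)c3)cc(-c3ccccc3O)n2)cc1` is not yet measured. It differs from compound 2 by 4-hydroxyphenyl in place of 3-hydroxyphenyl on an aromatic carbon. Compound 1 also carries the 4-hydroxyphenyl, yet it differs from compound 2 in a second place too, so its limit offers only a hint. The step from compound 2 to compound 3 is expected to run toward weaker inhibition, a 5.5-fold higher number from compound 2 to compound 3 (0.74 log units; beyond the scatter). Compound 3 is estimated at 15000 nM, between 4000 nM and 50000 nM.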

Compound 3, half-maximal inhibitory concentration: > 50000 nM
Compound 3: no number, only a limit; the forecaster's own chance of this, stated with the estimate: 35%; middle value at least 3.3-fold (0.52 log units) from the limit.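

Swapping 3-hydroxyphenyl for 4-hydroxyphenyl next to the ring nitrogen, with the trifluoromethoxy group unchanged, gives an at least 18-fold higher number from compound 2 to compound 3 (1.26 log units; beyond the scatter), so the place of a single hydroxyl on this ring matters greatly. Compound 1 offered only a hint of this, whereas this pair differs in one place alone. The step from compound 1 to compound 3 cannot be read, which leaves trifluoromethoxy against fluoro unresolved: the limit of > 50000 nM in this assay, at which 2 of the 3 values shown sit.

From the compounds shown here alone, whether 3-hydroxyphenyl would also outperform 4-hydroxyphenyl with fluoro on the other ring remains open. So does how an aminophenyl or a benzoic acid group would fare at this position.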